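This account rests on a few compounds, and the source may have more. Where it says the series, first, only, none or still open, it means among the compounds named here.

Measured so far in a functional assay on A549 cells (Homo sapiens) for antiproliferative activity, read by MTT assay, with a stated time of 48 h; on this read-out lower numbers stand for stronger inhibition and higher numbers for weaker inhibition:
- compound 1 `Cc1ccccc1-n1nncc1CN1C(=O)C2(C(C#N)=C(N)Oc3c(N)cc4nc5ccccc5nc4c32)c2ccccc21`: 31700 nM
- compound 2 `N#CC1=C(N)Oc2c(N)cc3nc4ccccc4nc3c2C12C(=O)N(Cc1cnnn1-c1ccc(Cl)cc1)c1ccccc12`: a limit only, > 50000 nM
- compound 3 `N#CC1=C(N)Oc2c(N)cc3nc4ccccc4nc3c2C12C(=O)N(Cc1cnnn1-c1cccc(Br)c1)c1ccccc12`: 18900 nM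

Compound 3 holds the lowest of the two numbers in this assay; compound 1 sits nearest, and the step of a 1.7-fold lower number from compound 1 to compound 3 (0.22 log units; within the scatter) keeps the two inside the scatter. The value of compound 2 is a limit, not a number (the limit of > 50000 nM in this assay, at which 1 of the 3 values shown sits). Against it the step of an at least 2.6-fold lower number from compound 2 to compound 3 (0.42 log units; beyond the scatter) is a real separation, while an at least 1.5-fold higher number from compound 1 to compound 2 (0.19 log units; that floor lies within the scatter) rests on a floor that stays inside the scatter.

Compound 4 `COc1ccccc1-n1nncc1CN1C(=O)C2(C(C#N)=C(N)Oc3c(N)cc4nc5ccccc5nc4c32)c2ccccc21` differs from compound 3 by 2-methoxyphenyl in place of 3-bromophenyl on an aromatic nitrogen. Among the measured compounds shown here, the only guide is the pair of compound 1 and compound 3, where a 2-methylphenyl on the same aromatic nitrogen gave a 1.7-fold lower number from compound 1 to compound 3 (0.22 log units; within the scatter); a 2-methoxyphenyl is expected to put compound 4 back near compound 1, so the expected step of a 1.5-fold higher number from compound 3 to compound 4 (0.17 log units; within the scatter) stays inside the scatter. Compound 4 is therefore estimated at 28000 nM, with the range 12000 nM to 60000 nM.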

Compound 4, half-maximal inhibitory concentration: 37500 nM
Beside the measured number, compound 4's estimate is 1.3-fold (0.13 log units) below it; the range from low to high includes it.
By their numbers in this assay, from the lowest: compounds 3, 1 and 4 (each within the scatter of the next). At a limit, above all of these: compound 2.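

In this assay, methoxy and methyl on the aromatic carbon of the phenyl ring cannot be told apart, as the step of a 1.2-fold higher number from compound 1 to compound 4 (0.07 log units; within the scatter) shows. The step of a 2.0-fold higher number from compound 3 to compound 4 (0.30 log units; within the scatter) also stays within the scatter, so 2-methoxyphenyl, 2-methylphenyl and 3-bromophenyl on this aromatic nitrogen give no separable numbers in compound 4, compound 1 and compound 3. The step of an at least 1.3-fold lower number from compound 2 to compound 4 (0.12 log units; that floor lies within the scatter) rests on a floor that separates nothing, and the value of compound 2 is a limit, not a number: the limit of > 50000 nM in this assay, at which 1 of the 4 values shown sits.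

On these data alone, whether any phenyl substituent can move the number clearly below this band remains open. A carboxylic acid, an amine or a longer chain such as butoxy on the phenyl ring would test that.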